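Dienone series on colon carcinoma cells: working notes

The source may report more compounds than this note shows. Statements on the series, on what has been measured and on what is new or still open speak of the compounds shown alone.

Of the compounds shown here, three carry numbers so far. Compound 1 `COc1ccc(/C=C/C(=O)/C=C/c2ccc(OCc3cn(CCCCCOc4cc(=O)oc5ccccc45)nn3)c(OC)c2)cc1OC` gives 45% in a functional assay on HCT-116 cells (Homo sapiens) for inhibition, read by sulforhodamine B assay, with a stated time of 48 h, tested at 50 uM; a lower number here means less inhibition of growth, a higher number more inhibition of growth at the concentration tested. Compound 2 `COc1ccc(/C=C/C(=O)/C=C/c2ccc(OCc3cn(CCOc4cc(=O)oc5ccccc45)nn3)c(OC)c2)cc1OC` gives 82% in this assay, the highest of the three numbers, and compound 3 `COc1cc(/C=C/C(=O)/C=C/c2ccccc2)ccc1OCc1cn(CCCCCOc2cc(=O)oc3ccccc23)nn1` gives 24%. The difference between the core of compound 1 and the core of compound 2 is not broken down here. From compound 1 to compound 3 the change is phenyl in place of 3,4-dimethoxyphenyl on a double-bonded chain carbon bound to a double-bonded chain carbon, and this gave a number 21 percentage points lower from compound 1 to compound 3 (beyond the scatter).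

Compound 4 `COc1cc(/C=C/C(=O)/C=C/c2ccccc2)ccc1OCc1cn(CCOc2cc(=O)oc3ccccc23)nn1` is not yet measured. It differs from compound 2 by phenyl in place of 3,4-dimethoxyphenyl on a double-bonded chain carbon bound to a double-bonded chain carbon, at the same place and of the same kind as the change from compound 1 to compound 3, so the two changes are one and the same change. The step is expected to be a number 22 percentage points lower from compound 2 to compound 4 (beyond the scatter), because the same change gave a number 21 percentage points lower from compound 1 to compound 3 (beyond the scatter). Going by the values given here, only one earlier instance of the change is available, so the expectation rests on a single measured pair and is held with a wide range. Compound 4 is accordingly estimated at 60% in this assay, with a range from 42% to 76%.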

Compound 4, percent growth inhibition at one concentration: 56%
For compound 4 the middle estimate is 4 percentage points above the measured one; low and high end bracket the measured number.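

The change from 3,4-dimethoxyphenyl to phenyl gives a number 26 percentage points lower from compound 2 to compound 4 (beyond the scatter) in this assay. Set beside the earlier instance, the step carries from one core to the other with no difference in size that can be told apart: the same change on two cores in this assay, a number 21 percentage points lower (beyond the scatter) from compound 1 to compound 3 and a number 26 percentage points lower (beyond the scatter) from compound 2 to compound 4, 5 percentage points apart, within the scatter of two such steps This shows that, for these two pairs, the change lowers growth inhibition to a similar extent on the core of compound 1 and the core of compound 2, but it rests on two pairs at one concentration in one cell line and does not show that the step would hold on any other core or explain why it occurs.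

The compounds shown leave open whether the step depends on both methoxy groups or on only one, since a methoxyphenyl, a hydroxyphenyl or a chlorophenyl group does not appear among them. Also open, from the compounds shown here alone, is how the change behaves on a core with a chain ending in an amine or a carboxylic acid.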